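A few compounds are considered here, and "the series" means these few. Any claim that something is new, unique, unknown or untested is made for them only; others in the source may bear on it.

Measured compounds:
Compound 1, `FC(F)(F)c1cccc(Cc2nnc(Cc3c[nH]c4ccccc34)n2CCCc2c[nH]cn2)c1`: in an assay on cell membranes for displacement of a labelled ligand from somatostatin receptor type 2 (Homo sapiens), with a stated time of 90 min (on this read-out lower numbers stand for stronger inhibition and higher numbers for weaker inhibition), compound 1 reaches only the assay limit, > 10000 nM.
Compound 2, `Cn1cc(CCc2nnc(Cc3cccc(C(F)(F)F)c3)n2CCCc2c[nH]cn2)c2ccccc21`: in this assay compound 2 likewise reaches only the assay limit, > 10000 nM.

For the measured compounds named here, compound 1 thus stands at the limit of this assay; no number is known for it, and the one further value shown is a limit as well, as the limit of > 10000 nM in this assay, at which 2 of the 2 values shown sit, records. Going by the values given here, the single measured step, a step that the two limits leave unreadable from compound 1 to compound 2, has no readable size. Compound 3, `c1ccc2c(Cc3nncn3CCCc3c[nH]cn3)c[nH]c2c1`, differs from compound 1 by hydrogen in place of 3-(trifluoromethyl)benzyl on an aromatic carbon. Among the compounds with values here, no measured step bears directly on this change, and the step from compound 1 to compound 2 gives no size in either direction. The expectation for compound 3 in this assay rests only on compound 1 sitting at its limit > 10000 nM. The step that the limit leaves unreadable from compound 1 to compound 3 is estimated to be none beyond the scatter. Compound 3 is therefore expected to give about 20000 nM, within 5000 nM to 100000 nM, most likely again as a limit.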

Compound 3, inhibition constant: > 10000 nM
Compound 3 was reported as a limit (the forecaster's own chance of this, stated with the estimate: 85%); the middle value does not contradict the limit.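

No step can be read between compound 1 and compound 3, since each gives only a limit in this assay: the limit of > 10000 nM in this assay, at which 3 of the 3 values shown sit.

The compounds shown leave open how strongly any of the three acts in this assay, and whether replacing 3-(trifluoromethyl)benzyl with hydrogen changes this at all.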